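This account rests on a few compounds, and the source may have more. Where it says the series, first, only, none or still open, it means among the compounds named here.

Compound 1, `COc1ccccc1NC(=S)N/N=C/c1ccc2ccccc2n1`, was examined in a functional assay on SGC-7901 cells (Homo sapiens) for antiproliferative activity, read by sulforhodamine B assay, with a stated time of 72 h; on this read-out lower numbers stand for stronger inhibition and higher numbers for weaker inhibition. In this assay compound 1 gives > 100000 nM, which is a limit of the assay and not a measured number. Two further compounds built on related cores give a sense of where the series stands. Compound 2, `NC(=S)N/N=C/c1cc2cccnc2s1`, in this assay gives 100000 nM. Compound 3, `NC(=S)N/N=C/c1ccc2cccnc2n1`, in this assay gives > 100000 nM, again a limit rather than a number. Going by the values given here, compound 1 therefore stands at the limit of > 100000 nM in this assay, at which 2 of the 3 values shown sit, and the one numerical value in the set, that of compound 2, sits at the same concentration. Among the compounds with values here, no pair of measured compounds differs in a single place, so no measured step can be drawn from these data.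

Compound 4, `S=C(N/N=C/c1ccc2ccccc2n1)Nc1ccc(Br)cc1`, has not been measured in this assay. It differs from compound 1 by 4-bromophenyl in place of 2-methoxyphenyl on an amide-type nitrogen. The measured compounds give no guidance on what this exchange does. The step from compound 1 to compound 4 in this assay is expected to be a number no higher from compound 1 to compound 4 (the limit leaves the size open), a change not beyond the usual scatter in either direction. For compound 4 the estimated value in this assay is 100000 nM, with a range from 30000 nM to 300000 nM.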

Compound 4, half-maximal inhibitory concentration: 69400 nM
Compound 4: the middle estimate sits 1.4-fold (0.16 log units) above what was measured, within the range that was stated.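

On the amide-type nitrogen of the core of compound 1, 4-bromophenyl in place of 2-methoxyphenyl yields a numerical reading in this assay: compound 4 gives 69400 nM. Compound 1 gives > 100000 nM, which is a limit of the assay and not a number. The change at this position can therefore be read only as an at least 1.4-fold lower number from compound 1 to compound 4 (0.15 log units; that floor lies within the scatter), and its true size stays open, since one end of the step is a limit: the limit of > 100000 nM in this assay, at which 2 of the 4 values shown sit.

The compounds shown do not separate the part played by the bromine, by its place on the ring or by the departure of the methoxy group; none of them carries a plain phenyl, a 2-bromophenyl or a 4-methoxyphenyl on this nitrogen. They also leave open how this assay would read with a group of another kind there, such as a benzyl group, a butyl chain or a phenyl ring bearing a carboxylic acid.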